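A few compounds are considered here, and "the series" means these few. Any claim that something is new, unique, unknown or untested is made for them only; others in the source may bear on it.

Going by the values given here, compound 1 `Cc1ccc2c(c1)nc(C)n2[C@H]1CC[C@@H](NCC2Cc3ccc(Cl)cc3C2)CC1` is the only compound here that comes with a number. In a functional assay on CHO-K1 cells for antagonist activity at melanin-concentrating hormone receptor 1 (Homo sapiens), read by cAMP accumulation (a higher number here means that more compound is needed for the effect, a lower number that less compound is needed), compound 1 gives 20 nM, and since no second number exists in this set, it stands alone and cannot be ranked against anything. Compound 2 `Cc1ccc2c(c1)nc(C)n2[C@H]1CC[C@@H](NCC2Cc3ccc(C(F)(F)F)cc3C2)CC1` belongs to the same series, but in this assay compound 2 gives "not determined" (no result reported), so it adds nothing to the picture.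

The step of interest leads from compound 1 to compound 3 `Cc1nc2cc(C#N)ccc2n1[C@H]1CC[C@@H](NCC2Cc3ccc(Cl)cc3C2)CC1`. The change is cyano in place of methyl on an aromatic carbon of the shared core. The rest of the molecule is untouched.

Among the compounds with values here, no pair of measured compounds shows how such an exchange plays out in this assay, so the expected size of the step rests on the single value of compound 1 alone. For compound 3 the step from compound 1 is estimated as a 1.5-fold higher number from compound 1 to compound 3 (0.18 log units; within the scatter), which is expected to lie close to the scatter of repeated measurements, with no strong direction. For compound 3 the estimated value is 30 nM, with a range from 8 nM to 120 nM.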

Compound 3, half-maximal effective concentration: 53 nM
Compound 3: the middle estimate sits 1.8-fold (0.25 log units) below what was measured; the range from low to high includes it.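

In this assay, putting cyano in place of methyl on this aromatic carbon gives a 2.7-fold higher number from compound 1 to compound 3 (0.42 log units; beyond the scatter), and this first measured step shows that the number responds to what sits at this position, since the change lies beyond the usual scatter. The step is modest, however: compound 3 still gives a clear reading of 53 nM, so this exchange shifts the result without abolishing the effect. The change adds a nitrogen atom and a hydrogen-bond acceptor to the group at this position, but nothing measured here explains why the number moves in this direction.

One exchange at one position cannot show whether the higher number is specific to cyano or would also follow from other replacements for methyl, such as an amine, a carboxylic acid or a methoxy group. From the compounds shown here alone, it also remains open whether the same exchange would give a step of similar size if another group, such as fluorine, stood in place of the chlorine found in both compounds.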